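A few compounds are considered here, and "the series" means these few. Any claim that something is new, unique, unknown or untested is made for them only; others in the source may bear on it.

Compound 1 `CN[C@H](C(=O)OC(C)OC(=O)N1CCN(c2cc3c(cc2F)c(=O)c(C(=O)O)cn3C2CC2)CC1)C(C)C` gives 2.4 h in a physicochemical assay for pharmacokinetics, read by HPLC, at pH 7.5; a higher number here means that the compound lasts longer, a lower number that the compound disappears faster. Compound 2 `CC(OC(=O)[C@H](C)NC(=O)c1ccccc1)OC(=O)N1CCN(c2cc3c(cc2F)c(=O)c(C(=O)O)cn3C2CC2)CC1` shares the same core and differs from it in one place. In this assay compound 2 reaches only a limit of the assay rather than a number: > 60 h, which is the limit of > 60 h in this assay, at which 1 of the 2 values shown sits. Putting 1-benzamidoethyl in place of 2-methyl-1-(methylamino)propyl on a carbonyl carbon brought an at least 25-fold higher number from compound 1 to compound 2 (1.39 log units; beyond the scatter). Compound 3 `CC(OC(=O)[C@@H](NC(=O)c1ccccc1)C(C)C)OC(=O)N1CCN(c2cc3c(cc2F)c(=O)c(C(=O)O)cn3C2CC2)CC1` has not been measured; it differs from compound 2 by isopropyl in place of methyl on a saturated chain carbon bound to an amide-type nitrogen and a carbonyl carbon. This change sits on the same chain carbon as the measured step, but that step also exchanged a methylamino for a benzamido group, so it bears on compound 3 only in part. Swapping methyl for isopropyl alone is expected to give no step beyond the scatter. Compound 3 is therefore expected to sit at or near the limit, at 60 h within 15 h to 250 h. That estimate means a number no higher from compound 2 to compound 3 (the limit leaves the size open).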

Compound 3, half-life: > 130 h
Compound 3 was reported as a limit; the forecaster's own chance of this, stated with the estimate: 70%; at least 2.1-fold (0.33 log units) between middle value and limit.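

Compound 1 and compound 3 both carry isopropyl on this chain carbon, so benzoyl in place of methyl on the amine nitrogen can be read on its own here, without the change of chain group that was mixed into the earlier step, and it brings an at least 54-fold higher number from compound 1 to compound 3 (1.73 log units; beyond the scatter). In this assay compound 3 gives > 130 h, which is a limit and not a number: the limit of > 130 h in this assay, at which 1 of the 3 values shown sits. Compound 2 gives > 60 h, which is also a limit: the limit of > 60 h in this assay, at which 1 of the 3 values shown sits.

As far as these compounds go, the step between compound 2 and compound 3 cannot be read, so how isopropyl and methyl on this chain carbon compare in this assay stays open. Also open, from the compounds shown here alone, is how an acetyl group on the amine nitrogen, or a free amine with a longer chain on the carbon, would compare with these compounds.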